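Chloro for dimethoxy on the pendant phenyl of compound 3

The source may hold more compounds than are shown below. What is called first, only, known or untested is meant among the compounds shown, and "the series" means these compounds.

Three analogues share a core in which a pendant phenyl on the pyrimidinone-type ring is varied. Compound 1 `Cc1nc(-c2ccc(Cl)cc2)sc1C(=O)CSc1nc(-c2ccccc2)c(C#N)c(=O)[nH]1` carries plain phenyl and in a functional assay on U-87MG ATCC cells for antiproliferative activity against U-87 MG (Homo sapiens), read by MTT assay, with a stated time of 48 h, tested at 10 uM (on this read-out higher numbers stand for a weaker effect at the one concentration tested and lower numbers for a stronger effect), compound 1 gives 83.1%. Compound 2 `Cc1nc(-c2ccc(Cl)cc2)sc1C(=O)CSc1nc(-c2cccc(Cl)c2)c(C#N)c(=O)[nH]1` carries 3-chlorophenyl; compound 2 gives 95.2%. Compound 3 `COc1ccc(-c2nc(SCC(=O)c3sc(-c4ccc(Cl)cc4)nc3C)[nH]c(=O)c2C#N)cc1OC` carries 3,4-dimethoxyphenyl; compound 3 gives 83.3%. Compound 3 thus stands second highest of the three, within the scatter of compound 1 and separated from compound 2 by a number 11.9 percentage points lower from compound 2 to compound 3 (beyond the scatter).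

Compound 4 `Cc1nc(-c2ccc(Cl)cc2)sc1C(=O)CSc1nc(-c2ccc(Cl)cc2)c(C#N)c(=O)[nH]1` differs from compound 3 in one place: 4-chlorophenyl in place of 3,4-dimethoxyphenyl on an aromatic carbon

Within the data shown here, two measured steps bear on this change. The step of a number 12.1 percentage points higher from compound 1 to compound 2 (beyond the scatter) shows that a chloro on the pendant phenyl raised the number beyond the scatter, and the step of a number 11.9 percentage points lower from compound 2 to compound 3 (beyond the scatter) shows that replacing that chlorophenyl with the dimethoxyphenyl lowered it by a similar amount. Compound 4 reintroduces a chlorophenyl, so a step upward of modest size is expected, a number 7.7 percentage points higher from compound 3 to compound 4 (within the scatter), toward the region of compound 2. Compound 4 is therefore estimated at 91%, with a range from 79% to 100%.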

Compound 4, a percentage reported as activity, at one concentration (the size of the read-out at that concentration, not a potency): 98.4%
Compound 4: the middle estimate sits 7.4 percentage points below what was measured; low and high end bracket the measured number.
By their numbers in this assay, from the lowest: compounds 1 and 3 (each within the scatter of the next); then compounds 2 and 4 (each within the scatter of the next).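

In this assay, the position next to the ring nitrogen tolerates a shift of the chloro around the pendant ring without a separable change, since the step of a number 3.2 percentage points higher from compound 2 to compound 4 (within the scatter) stays within the scatter, so 4-chlorophenyl and 3-chlorophenyl cannot be told apart here. The steps of a number 15.3 percentage points higher from compound 1 to compound 4 (beyond the scatter) and a number 15.1 percentage points higher from compound 3 to compound 4 (beyond the scatter) show that 4-chlorophenyl, like 3-chlorophenyl, leaves the number beyond the scatter on the weaker side of both phenyl and 3,4-dimethoxyphenyl, so the four compounds fall into two groups, with both chlorophenyl compounds in one and none going against this split. Nothing available accounts for this difference between the two groups, and no cause can be assigned to it.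

From the compounds shown here alone, it remains open whether an amine or a carboxylic acid on the pendant phenyl would take the number below the level of compound 1 and compound 3, or whether a single methoxy would sit with those two or with the chlorophenyl pair. Going by these compounds, all of these numbers come from one concentration, so the order of potency across the series also stays open.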